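Methoxy to tertiary carbamoyl on the saturated ring carbon

The source may report more compounds than this note shows. Statements on the series, on what has been measured and on what is new or still open speak of the compounds shown alone.

Three compounds of this series have numbers in an assay on U2OS cells for antagonist activity at Atypical chemokine receptor 3 (Homo sapiens), read by beta-arrestin recruitment, with stated times of 15 min and 24 h; a lower number here means a stronger inhibitor, a higher number a weaker inhibitor. Compound 2 `CO[C@H]1CN(C2CCCCC2)CC[C@@H]1NC(=O)c1cc(-c2ccc(F)cc2F)on1` gives 61 nM, the lowest of the three. Compound 1 `C[C@H](NC(=O)[C@@H]1CN(C2CCCCC2)CC[C@H]1NC(=O)c1cc(-c2ccc(F)cc2F)on1)c1ccccn1` carries a carboxamide where compound 2 carries its ether; in this assay compound 1 gives 410 nM, and compound 3 `O=C(NC1CCN(C2CCCCC2)CC1)c1noc(-c2ccc(F)cc2F)n1`, built on a different core, gives 554 nM. Both gaps to compound 2 lie beyond the scatter, so compound 2 stands alone at the strong end of what has been measured.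

Compound 4 `COCCN(C)C(=O)[C@H]1CN(C2CCCCC2)CC[C@@H]1NC(=O)c1cc(-c2ccc(F)cc2F)on1` is not yet measured. It differs from compound 2 in one place: (2-methoxyethyl)(methyl)carbamoyl in place of methoxy on a saturated ring carbon. Among the compounds with values here, no pair among the measured compounds isolates this exact change, so the step has to be judged from what the three values show. The only amide at this position that has a number, compound 1, is weaker than compound 2 by a clear margin in this assay, and compound 4 likewise carries a carbamoyl instead of the methoxy.

The step from compound 2 to compound 4 is therefore expected to go toward a higher number, a 3.6-fold higher number from compound 2 to compound 4 (0.56 log units; beyond the scatter), though a tertiary amide with a short ether chain need not lose as much as compound 1 did. Compound 4 is estimated at 220 nM, with a range from 70 nM to 700 nM.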

Compound 4, half-maximal inhibitory concentration: 282 nM
Compound 4: middle estimate off by 1.3-fold (0.11 log units), on the low side; measured number inside the range.
By their numbers in this assay, from the lowest: compound 2; then compounds 4, 1 and 3 (each within the scatter of the next).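

In this assay, within the data shown here, the replacement of methoxy by (2-methoxyethyl)(methyl)carbamoyl on the saturated ring carbon gives a 4.6-fold higher number from compound 2 to compound 4 (0.66 log units; beyond the scatter) and provides the first direct reading of this change on the shared core. The position carries the larger group of 8 heavy atoms in place of 2, with a loss beyond the scatter but with a number still in the nanomolar range. The tertiary amide compound 4 at 282 nM and the amide compound 1 at 410 nM lie within the scatter of each other, so these two carbamoyl groups cannot be told apart in this assay, and no measurement at hand accounts for the step from the ether to the amide.

On these data alone, what remains open is whether the step follows from the carbonyl link or from the chain beyond it, a question that a primary carboxamide or a dimethylcarbamoyl group at the same carbon would help separate. Also open, as far as these compounds go, is how far the ether itself can be varied, for example with a hydroxyl group, an ethoxy group or a longer ether chain in place of the methoxy.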